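This account rests on a few compounds, and the source may have more. Where it says the series, first, only, none or still open, it means among the compounds named here.

Three compounds have been measured so far in an ADME assay on MDBK cells (Bos taurus) for cytotoxicity, read by MTT assay, with a stated time of 96 h (a higher number here means that more compound is tolerated, a lower number that less compound is tolerated), and each reading is a limit of the assay and not a number:
Compound 1 (`C/C(=N\NC(N)=O)c1ccc2[nH]c(-c3ccccc3)nc2c1`): > 100000 nM
Compound 2 (`C/C(=N\NC(N)=O)c1ccc2[nH]c(-c3ccc(Cl)cc3)nc2c1`): > 100000 nM
Compound 3 (`C/C(=N\NC(N)=O)c1ccc2[nH]c(-c3ccoc3)nc2c1`): > 100000 nM

Compound 3 therefore stands at > 100000 nM, which is a limit. The other two compounds offer no number either: the limit of > 100000 nM in this assay, at which 3 of the 3 values shown sit. Compound 4 (`C/C(=N\NC(N)=O)c1ccc2[nH]c(C3CCCCC3)nc2c1`) keeps the shared core and carries cyclohexyl in place of furan-3-yl on an aromatic carbon. The measured steps that change the group at this place are a step that the two limits leave unreadable from compound 1 to compound 3 and a step that the two limits leave unreadable from compound 2 to compound 3. The chloro change gives a step that the two limits leave unreadable from compound 1 to compound 2. None of the three has a readable size, so none of them gives a direction. For the measured compounds named here, no measured compound carries a non-aromatic ring at this place, which leaves the new group untested. The expectation therefore rests on compound 3 and its limit of > 100000 nM, and another reading at that limit is the likeliest outcome. The expected step in this assay is a number no higher from compound 3 to compound 4 (the limit leaves the size open), with nothing beyond the scatter anticipated. For compound 4 the estimated value is 100000 nM, with an expected range from 40000 nM to 100000 nM.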

Compound 4, half-maximal cytotoxic concentration: > 100000 nM
Compound 4: only a limit was reported; the forecaster's own chance of this, stated with the estimate: 70%; the middle value sits exactly at the limit.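

In this assay compound 4 gives > 100000 nM, which is a limit of the assay and not a number. No step from compound 1, compound 2 or compound 3 to compound 4 can be read, because all four compounds rest on the same limit: the limit of > 100000 nM in this assay, at which 4 of the 4 values shown sit. The compounds shown leave open at what concentration any of them reaches the half-maximal cytotoxic effect, and whether the groups exchanged at this place differ at all in this assay.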